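Replacing a furan arm with a methyl on a sulfamate amide series

The compounds below may be only part of what the source reports. "The series", "measured", "known", "first", "only" and "open" are said of these compounds alone.

The three measured compounds share a sulfamate-bearing core carrying an amide to a substituted benzene. Compound 1 `NS(=O)(=O)Oc1ccc2c(c1)CN(C(=O)c1cccc(N3CCC(N4CCCCC4)CC3)c1)CC2` gives 8% in an assay on HEK293 cells for inhibition of Steryl-sulfatase (Homo sapiens), tested at 1 uM; a higher number here means a stronger effect of the compound at the concentration tested, a lower number a weaker effect. Compound 2 `CCN(Cc1ccc(Br)cc1)c1cccc(C(=O)N2CCc3ccc(OS(N)(=O)=O)cc3C2)c1` gives 84.5% in this assay. Compound 3 `NS(=O)(=O)Oc1ccc2c(c1)CN(C(=O)c1ccc(N(Cc3ccccc3)Cc3ccco3)cc1)CC2` gives 98.2% in this assay, the highest of the three numbers; its nearest neighbour is compound 2, and the gap between the two is beyond the scatter, as is the much larger gap to compound 1.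

Compound 4 `CCN(Cc1ccccc1)c1ccc(C(=O)N2CCc3ccc(OS(N)(=O)=O)cc3C2)cc1` is not yet measured. It differs from compound 3 in one place: methyl in place of furan-2-yl on a saturated chain carbon bound to a nitrogen on an aromatic ring. Among the compounds with values here, no measured pair shows this same change, so its size can only be expected from what the three numbers show. Compound 2, which also carries an ethyl on the aromatic nitrogen together with a benzyl-type arm, gives 84.5%, a high value. The step of a number 8.2 percentage points lower from compound 3 to compound 4 (within the scatter) is therefore expected to be small and downward, likely within the scatter. Compound 4 is estimated to give 90% in this assay, with a range from 72% to 99%.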

Compound 4, a percentage reported as inhibition, at one concentration (the size of the read-out at that concentration, not a potency) in the Steryl-sulfatase assay: 83.6%
The estimate for compound 4 lay 6.4 percentage points above the measured number; measured number inside the range.
By their numbers in the Steryl-sulfatase assay, from the lowest: compound 1; then compounds 4 and 2 (each within the scatter of the next); then compound 3.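

In the Steryl-sulfatase assay, methyl in place of furan-2-yl on a saturated chain carbon bound to a nitrogen on an aromatic ring gives a number 14.6 percentage points lower from compound 3 to compound 4 (beyond the scatter). Within the data shown here, this is the first direct reading of this position: the furan-2-yl matters to the number, yet with only a methyl in its place compound 4 still gives 83.6%. In a physicochemical assay for lipophilicity (a higher number here means a more lipophilic compound, a lower number a more polar compound), compound 3 gives 1.93 and compound 4 gives 3.08, so the same change runs the other way and within this pair the higher inhibition belongs to the less lipophilic compound: the measured partition coefficient of compound 3, 1.93, and of compound 4, 3.08, a number 1.15 log units higher (beyond the scatter)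

One pair cannot say whether the step follows the loss of the ring or of its oxygen. Going by these compounds, how a thiophen-2-yl, a phenyl or a longer chain such as propyl would read at this place remains open.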